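Second methoxy on the benzamide of compound 3

The source may report more compounds than this note shows. Statements on the series, on what has been measured and on what is new or still open speak of the compounds shown alone.

Working notes on the dimethoxy analogue. In an ADME assay on BaF3 cells (Mus musculus) for antiproliferative activity, read by CellTiter-Glo and CCK-8 assay, with a stated time of 72 h (a higher number here means a weaker inhibitor of growth, a lower number a stronger inhibitor of growth), compound 1 `CNc1nc(Nc2ccc(C)c([N+](=O)[O-])c2)ncc1C(=O)Nc1cc(NC(=O)c2cccc(C(F)(F)F)c2)ccc1C` returns only a limit, > 10000 nM. Compound 2 `CNc1nc(Nc2ccc(C)c([N+](=O)[O-])c2)ncc1C(=O)Nc1cc(NC(=O)c2cccc(OC)c2)ccc1C` gives a number in this assay, 6310 nM. Compound 3 `CNc1nc(Nc2ccc(C)c([N+](=O)[O-])c2)ncc1C(=O)Nc1cc(NC(=O)c2ccc(OC)cc2)ccc1C` again returns only a limit in this assay, > 10000 nM. Compound 3 therefore stands at the limit of > 10000 nM in this assay, at which 2 of the 3 values shown sit, with no number of its own. The measured steps read an at least 1.5-fold lower number from compound 1 to compound 2 (0.19 log units; that floor lies within the scatter) and an at least 1.5-fold higher number from compound 2 to compound 3 (0.19 log units; that floor lies within the scatter), while a step that the two limits leave unreadable from compound 1 to compound 3.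

Compound 4 `CNc1nc(Nc2ccc(C)c([N+](=O)[O-])c2)ncc1C(=O)Nc1cc(NC(=O)c2ccc(OC)c(OC)c2)ccc1C` differs from compound 3 by methoxy in place of hydrogen on an aromatic carbon. The step that bears on this change is an at least 1.5-fold higher number from compound 2 to compound 3 (0.19 log units; that floor lies within the scatter): the 3-methoxyphenyl amide of compound 2 gives a number where the 4-methoxyphenyl amide of compound 3 gives only a limit. For the measured compounds named here, compound 4 carries both methoxy groups, and no measured pair tests adding a methoxy while another is kept. Going by the values given here, its 4-methoxy group is the one shared with compound 3, so the expectation is a number at or close to the limit, with a move back toward the reading of compound 2 possible but unsupported by anything measured. Compound 4 is therefore expected near 9000 nM, within 3000 nM to 30000 nM. That estimate amounts to an expected step of an at least 1.1-fold lower number from compound 3 to compound 4 (0.04 log units; that floor lies within the scatter).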

Compound 4, concentration for 50% growth inhibition: 7300 nM
Beside the measured number, compound 4's estimate is 1.2-fold (0.09 log units) above it, and the stated range covers the measured number.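

Adding a methoxy to the 4-methoxyphenyl amide gives a number rather than a limit in this assay: the step reads an at least 1.3-fold lower number from compound 3 to compound 4 (0.13 log units; that floor lies within the scatter), so the 3,4-dimethoxyphenyl amide shows no gain beyond the scatter, though a larger true step cannot be excluded. Compared with the 3-methoxyphenyl amide, the added 4-methoxy reads a 1.2-fold higher number from compound 2 to compound 4 (0.06 log units; within the scatter), so the two amides cannot be told apart in this assay, and the 4-methoxy group shared with compound 3 does not by itself tie the series to a limit once a 3-methoxy group is also present. Replacing 3-(trifluoromethyl)phenyl with 3,4-dimethoxyphenyl reads an at least 1.3-fold lower number from compound 1 to compound 4 (0.13 log units; that floor lies within the scatter), and the set as a whole stays close to the top of the range of this assay: the limit of > 10000 nM in this assay, at which 2 of the 4 values shown sit.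

The compounds shown therefore give no step that is established beyond the scatter, and the true values behind the two limits stay unknown. On these data alone, how an amine, a carboxylic acid or a longer alkoxy chain on this aromatic ring would read remains open, as does the reading of the plain benzoyl amide with hydrogen at both places.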